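This account rests on a few compounds, and the source may have more. Where it says the series, first, only, none or still open, it means among the compounds named here.

Measured in a functional assay on HUVEC cells (Homo sapiens) for inhibition; a lower number here means a stronger inhibitor, a higher number a weaker inhibitor:
- compound 1 `COc1cc(/C=C/C(=O)c2cccc(NC(=O)c3c(Cl)cccc3Cl)c2)ccc1O`: 0.46 ug/mL
- compound 2 `COc1cc(/C=C/C(=O)c2cccc(NC(=O)C(C)C)c2)ccc1O`: 1.44 ug/mL

Compound 2 has the higher number of the pair, which makes it the weaker inhibitor, and the gap lies beyond the scatter. Compound 3 `CCOC(=O)C(=O)Nc1cccc(C(=O)/C=C/c2ccc(O)c(OC)c2)c1` carries ethoxycarbonyl in place of isopropyl on a carbonyl carbon. Going by the values given here, only one measured step touches this place, a 3.1-fold higher number from compound 1 to compound 2 (0.50 log units; beyond the scatter). Among the compounds with values here, it is modest, and no measured compound carries ethoxycarbonyl, so the direction stays open. Little change is therefore expected in this assay, with an estimated 1.2-fold lower number from compound 2 to compound 3 (0.08 log units; within the scatter), which is no step beyond the scatter. For compound 3 the expected value is 1.2 ug/mL, with an estimated range from 0.4 ug/mL to 3.5 ug/mL.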

Compound 3, half-maximal inhibitory concentration: 13.3 ug/mL
Beside the measured number, compound 3's estimate is 11-fold (1.04 log units) below it; the whole stated range lies below it.
By their numbers in this assay, from the lowest: compound 1; then compound 2; then compound 3.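

In this assay, the group on this carbonyl carbon matters more than the first pair showed: putting ethoxycarbonyl in place of isopropyl gives a 9.2-fold higher number from compound 2 to compound 3 (0.97 log units; beyond the scatter), a wider gap than the earlier step. Putting it in place of 2,6-dichlorophenyl gives a 29-fold higher number from compound 1 to compound 3 (1.46 log units; beyond the scatter), so compound 3 is the weakest inhibitor of the three. Nothing available explains these steps.

Going by these compounds, whether the ethyl ester end or the added carbonyl drives the loss remains open. A carboxylic acid or a primary amide in place of ethoxycarbonyl could separate the two.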